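Swapping Piperidin-1-yl for an Ethoxyanilino Group on a Shared Core

The compounds below may be only part of what the source reports. "The series", "measured", "known", "first", "only" and "open" are said of these compounds alone.

Compound 1 `FC(F)(F)c1ccc(CSc2nc(N3CCCCC3)c3ccccc3n2)cc1` is tested in a functional assay on MGC-803 cells (Homo sapiens) for cytotoxicity, read by MTT assay, with a stated time of 72 h (on this read-out higher numbers stand for weaker inhibition and lower numbers for stronger inhibition), and gives 18600 nM. Among the measured compounds shown here, only two definite numbers exist so far, and the other belongs to compound 2 `FC(F)(F)c1ccc(CSc2nc(Nc3ccccc3)c3ccccc3n2)cc1`, which in this assay gives 22200 nM; the gap between them is within the usual scatter, so the two cannot be told apart: a 1.2-fold higher number from compound 1 to compound 2 (0.08 log units; within the scatter). Compound 3 `FC(F)(F)c1ccc(CSc2nc(Nc3ccccc3C(F)(F)F)c3ccccc3n2)cc1` reaches only the limit of the assay, > 50000 nM, so its number is not known. The two steps toward compound 3 are larger, an at least 2.6-fold higher number from compound 1 to compound 3 (0.42 log units; beyond the scatter) and an at least 2.2-fold higher number from compound 2 to compound 3 (0.35 log units; beyond the scatter), and both rest on (the limit of > 50000 nM in this assay, at which 1 of the 3 values shown sits).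

Compound 4 `CCOc1ccc(Nc2nc(SCc3ccc(C(F)(F)F)cc3)nc3ccccc23)cc1` has not yet been measured. It differs from compound 1 in one place: (4-ethoxyphenyl)amino in place of piperidin-1-yl on an aromatic carbon. The step from compound 1 to compound 2 bears on it most closely, as it likewise replaces piperidin-1-yl with an anilino group, and that step stayed within the scatter. Compound 3 carries a trifluoromethyl on the anilino ring and sits at the limit. For the measured compounds named here, compound 4 instead carries an ethoxy group, for which no measured step exists. The expected change is therefore small, a 1.1-fold higher number from compound 1 to compound 4 (0.03 log units; within the scatter), with no clear direction beyond the scatter. Compound 4 is estimated at 20000 nM, within the range 6000 nM to 60000 nM.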

Compound 4, half-maximal inhibitory concentration: 37000 nM
Compound 4: the middle estimate sits 1.9-fold (0.27 log units) below what was measured; measured number inside the range.
By their numbers in this assay, from the lowest: compounds 1, 2 and 4 (each within the scatter of the next). At a limit, above all of these: compound 3.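

In this assay, ethoxy on the anilino ring now has a measured step of its own: a 1.7-fold higher number from compound 2 to compound 4 (0.22 log units; within the scatter), so ethoxy in place of hydrogen does not separate these two compounds. The step of a 2.0-fold higher number from compound 1 to compound 4 (0.30 log units; within the scatter) is also within the scatter, which means that piperidin-1-yl, anilino and (4-ethoxyphenyl)amino on this aromatic carbon, next to the ring nitrogen, give values in compounds 1, 2 and 4 that cannot be told apart, while compound 3, which carries a trifluoromethyl on the anilino ring, goes against this picture by sitting at a limit. The comparison with that limit shows an at least 1.3-fold lower number from compound 3 to compound 4 (0.13 log units; that floor lies within the scatter), so even compound 4 cannot be firmly placed apart from compound 3, whose true number is unknown: the limit of > 50000 nM in this assay, at which 1 of the 4 values shown sits.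

The compounds shown leave open whether any group at this position would give a clear step toward stronger inhibition, such as a morpholin-4-yl ring, a dimethylamino group or an anilino ring bearing a carboxylic acid. They also leave open whether a longer chain, such as butoxy, in place of the ethoxy would stay within the scatter of compound 4.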